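Methyl for nitro on a chalcone: expected shift

The compounds below may be only part of what the source reports. "The series", "measured", "known", "first", "only" and "open" are said of these compounds alone.

Measured compounds:
compound 1, `O=C(/C=C/c1cccc(OCc2ccccc2)c1)c1ccccc1Br`, 1600 nM
compound 2, `O=C(/C=C/c1cccc(OCc2ccccc2)c1)c1ccc([N+](=O)[O-])cc1`, 17500 nM
compound 3, `COc1cc(C2Oc3cc(/C=C/C(=O)c4ccccc4O)ccc3OC2CO)ccc1O`, 12100 nM

These three were tested in a functional assay on MCF7 cells (Homo sapiens) for cytotoxicity, read by MTT assay, with a stated time of 68 h; on this read-out lower numbers stand for stronger inhibition and higher numbers for weaker inhibition. Compound 2 shows the highest number of the three, so the weakest inhibition; compound 3 sits within the scatter of it, while compound 1 lies well beyond the scatter with a much lower number. For the measured compounds named here, the one directly comparable step, an 11-fold higher number from compound 1 to compound 2 (1.04 log units; beyond the scatter), came from exchanging the ring on the carbonyl carbon, which shows that this part of the molecule can move the result strongly.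

Compound 4, `Cc1ccc(C(=O)/C=C/c2cccc(OCc3ccccc3)c2)cc1`, differs from compound 2 by methyl in place of nitro on an aromatic carbon. Going by the values given here, no measured pair shows the effect of this particular exchange, so only the large sensitivity of this position seen in an 11-fold higher number from compound 1 to compound 2 (1.04 log units; beyond the scatter) can guide the expectation. A moderate move toward a lower number than compound 2 is expected, a 2.2-fold lower number from compound 2 to compound 4 (0.34 log units; beyond the scatter), though a result within the scatter cannot be excluded. For compound 4 the estimated value is 8000 nM, with a likely range from 2500 nM to 25000 nM.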

Compound 4, half-maximal inhibitory concentration: 21700 nM
Beside the measured number, compound 4's estimate is 2.7-fold (0.43 log units) below it, and the stated range covers the measured number.
By their numbers in this assay, from the lowest: compound 1; then compounds 3, 2 and 4 (each within the scatter of the next).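

Nitro and methyl on this aromatic carbon, para to a large group, cannot be told apart in this assay (a 1.2-fold higher number from compound 2 to compound 4 (0.09 log units; within the scatter)). The earlier large step therefore does not depend on the nitro group alone: with methyl in its place, the gap to the 2-bromophenyl compound remains large (a 14-fold higher number from compound 1 to compound 4 (1.13 log units; beyond the scatter)). Nothing measured here explains either result.

Still open, from the compounds shown here alone, is whether other groups at this spot, such as an amine or a carboxylic acid, would stay within the scatter of compound 2 and compound 4 or reach the much lower number of compound 1. Going by these compounds, it is also open whether the lower number of compound 1 comes from the bromine itself or from where it sits on the ring.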